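The source may report more compounds than this note shows. Statements on the series, on what has been measured and on what is new or still open speak of the compounds shown alone.

Measured so far:
- compound 1 `Cc1ccc(Oc2c(/C=N\OCc3c(Cl)c(-c4ccc(F)cc4)nn3C)c(C)nn2C)cc1`: 80%
- compound 2 `Cc1nn(C)c(Oc2ccc(Cl)cc2)c1/C=N\OCc1c(Cl)c(-c2ccc(Cl)cc2)nn1C`: 80%
- compound 3 `Cc1nn(C)c(Oc2ccc(Br)cc2)c1/C=N\OCc1c(Cl)c(-c2ccc(Cl)cc2)nn1C`: 80%

All three were tested in a functional assay on SMMC-7721 cells (Homo sapiens) for inhibition, read by MTT assay, with a stated time of 72 h, tested at 25 uM; on this read-out higher numbers stand for more inhibition at the one concentration tested (going by the name of the read-out) and lower numbers for less inhibition. Compound 3 stands level with compound 1 and compound 2 at the digits shown; in this assay compound 3 gives 80%. Among the measured compounds shown here, the one measured step, no change at the digits printed from compound 2 to compound 3 (within the scatter), lies within the scatter.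

The next compound, compound 4 `Cc1ccc(Oc2c(/C=N\OCc3c(Cl)c(-c4ccc(Cl)cc4)nn3C)c(C)nn2C)cc1`, differs from compound 3 at a single place: methyl in place of bromo on an aromatic carbon. No measured step exchanges bromo for methyl directly, but compound 1 already carries the 4-methylphenoxy group and gives 80%, the same reading at the digits shown as compound 3 with its 4-bromophenoxy group. The step that bears most nearly on the change, no change at the digits printed from compound 2 to compound 3 (within the scatter), was flat. Therefore no step beyond the scatter is expected in this assay, in either direction; the expected step is no change at the digits printed from compound 3 to compound 4 (within the scatter).

For compound 4 the estimate in this assay is 80%, with a range from 68% to 88%.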

Compound 4, a percentage reported as inhibition, at one concentration (the size of the read-out at that concentration, not a potency): 80%
Compound 4: middle estimate and measured number agree at the digits printed; low and high end bracket the measured number.
By their numbers in this assay, from the lowest: compounds 1, 2, 3 and 4 (each within the scatter of the next).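

Replacing the halogen with a carbon substituent on the phenoxy group is new here: in this assay methyl in place of bromo reads no change at the digits printed from compound 3 to compound 4 (within the scatter) and methyl in place of chloro reads no change at the digits printed from compound 2 to compound 4 (within the scatter) at this same place, para to a large group. A second halogen exchange, chloro in place of fluoro on an aromatic carbon, reads no change at the digits printed from compound 1 to compound 4 (within the scatter) in the same way, so neither change separates these compounds at the one concentration tested. No supporting measurement bears on why these readings coincide.

Still open, from the compounds shown here alone, is how this place responds to groups of another kind, such as an amine, a carboxylic acid or a longer alkyl chain. A single-concentration reading also leaves open whether these compounds would differ in potency across a range of concentrations.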